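From phenyl to 2-phenylethenyl: compound 1 to compound 4

This account rests on a few compounds, and the source may have more. Where it says the series, first, only, none or still open, it means among the compounds named here.

compound 1 `CN1CCC=C(c2ccc(CN(C)Cc3ccccc3)cc2)C1` gives > 50000 nM (a limit)
compound 2 `CN1CCC=C(c2ccc(CN(C)Cc3ccc([N+](=O)[O-])cc3)cc2)C1` gives 28000 nM (a number)
compound 3 `COC(=O)c1ccc(CN(C)Cc2ccc(C3=CCCN(C)C3)cc2)cc1` gives > 50000 nM (a limit)

In an ADME assay on HL-60 cells (Homo sapiens) for cytotoxicity, read by MTT assay, with a stated time of 24 h (a lower number here means a stronger inhibitor, a higher number a weaker inhibitor), compound 1 gives > 50000 nM (a limit, not a number). Among the measured compounds shown here, the series so far shows the limit of > 50000 nM in this assay, at which 2 of the 3 values shown sit, and only compound 2 has a measured number.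

Compound 4 `CN1CCC=C(c2ccc(CN(C)C/C=C/c3ccccc3)cc2)C1` differs from compound 1 by 2-phenylethenyl in place of phenyl on a saturated chain carbon bound to an amine nitrogen. The measured steps all change an aromatic carbon, not the chain, so they bear on this change only loosely. For the measured compounds named here, the one with compound 1 as its start and a readable floor is an at least 1.7-fold lower number from compound 1 to compound 2 (0.25 log units; that floor lies within the scatter) and that floor lies within the scatter. The step that the two limits leave unreadable from compound 1 to compound 3 cannot be sized, and an at least 1.7-fold higher number from compound 2 to compound 3 (0.25 log units; that floor lies within the scatter) also has a floor within the scatter.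

No step beyond the scatter is therefore expected in this assay for this change. The expected step is an at least 1.1-fold lower number from compound 1 to compound 4 (0.04 log units; that floor lies within the scatter) and a limit reading would be no surprise. For compound 4 the estimated value is 45000 nM with an expected range of 20000 nM to 90000 nM in this estimate.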

Compound 4, half-maximal inhibitory concentration: > 50000 nM
Compound 4: a limit, no number; the forecaster's own chance of this, stated with the estimate: 55%; middle value at least 1.1-fold (0.04 log units) away from the limit.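

In this assay compound 4 gives > 50000 nM, a limit and not a number. Among the compounds shown here, compound 1 also stands at a limit, so no step between compound 1 and compound 4 can be read. Left open is whether 2-phenylethenyl in place of phenyl on a saturated chain carbon bound to an amine nitrogen shifts the number at all.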